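This account rests on a few compounds, and the source may have more. Where it says the series, first, only, none or still open, it means among the compounds named here.

Compound 1, `Cc1[nH]c2ccccc2c1C1CC(c2ccncc2)=NO1`, gives 26600 nM in a functional assay on MDA-MB-231 cells (Homo sapiens) for inhibition, read by MTT assay, with a stated time of 48 h; on this read-out higher numbers stand for weaker inhibition and lower numbers for stronger inhibition. Compound 3, `Cc1c(C2CC(c3ccncc3)=NO2)c2ccccc2n1Cc1ccc(Cl)cc1`, differs from it by 4-chlorobenzyl in place of hydrogen on an aromatic nitrogen, and in this assay compound 3 gives 6660 nM, so that a 4.0-fold lower number from compound 1 to compound 3 (0.60 log units; beyond the scatter). Compound 2, `COc1ccc2c(C3CC(c4ccncc4)=NO3)c[nH]c2c1`, has a different core; the difference between the two cores is not broken down here. In this assay compound 2 gives 7380 nM, a number close to that of compound 3 and within the usual scatter of it, while the gap to compound 1 lies beyond the scatter.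

Compound 4, `COc1ccc2c(C3CC(c4ccncc4)=NO3)cn(Cc3ccc(Cl)cc3)c2c1`, differs from compound 2 by 4-chlorobenzyl in place of hydrogen on an aromatic nitrogen. This is the same kind of change as that from compound 1 to compound 3, though the surroundings differ: in compound 1 the aromatic nitrogen is next to the ring atom that bears a methyl group, whereas in compound 2 no such methyl group is present. Resting on the single earlier example, compound 4 is expected to show a step of a 3.0-fold lower number from compound 2 to compound 4 (0.47 log units; beyond the scatter) in this assay, which is estimated to place compound 4 at 2500 nM, with a likely range from 800 nM to 7500 nM.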

Compound 4, half-maximal inhibitory concentration: > 100000 nM
Compound 4: only a limit was reported; the forecaster's own chance of this, stated with the estimate: 5%; middle value at least 40-fold (1.60 log units) from the limit.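

In this assay, 4-chlorobenzyl in place of hydrogen on an aromatic nitrogen brings an at least 13-fold higher number from compound 2 to compound 4 (1.13 log units; beyond the scatter), and set beside the earlier step, the change does not carry over from one core to the other: the same change on two cores in this assay, a 4.0-fold lower number (0.60 log units; beyond the scatter) from compound 1 to compound 3 and an at least 13-fold higher number (1.13 log units; beyond the scatter) from compound 2 to compound 4, at least 54-fold (1.73 log units) apart, beyond the scatter of two such steps. Compound 4 stands at a limit of the assay and not at a number: the limit of > 100000 nM in this assay, at which 1 of the 4 values shown sits. With only these two pairs, the result shows that neither the size nor the direction of this change can be taken from one core to another in this series, but it does not show which difference between the cores goes with the reversal.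

As far as these compounds go, it remains open how a plain benzyl group, a methyl group or a longer alkyl chain in place of that hydrogen would behave on each core. The compounds shown also do not separate the methyl group of compound 1 from the methoxy group of compound 2, so neither can be tied to the different outcomes.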